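This account rests on a few compounds, and the source may have more. Where it says the series, first, only, none or still open, it means among the compounds named here.

Measured in a functional assay for inhibition of sodium/hydrogen exchanger (Oryctolagus cuniculus); a higher number here means a weaker inhibitor, a lower number a stronger inhibitor:
compound 1, `CCCc1cc(C)c(C(=O)N=C(N)N)cc1S(C)(=O)=O`, gives 5.7 nM;
compound 2, `CCC(C)c1cc(C)c(C(=O)N=C(N)N)cc1S(C)(=O)=O`, gives 8 nM;
compound 3, `CCOc1cc(C)c(C(=O)N=C(N)N)cc1S(C)(=O)=O`, gives 19 nM.

Compound 4, `Cc1cc(OC(C)C)c(S(C)(=O)=O)cc1C(=O)N=C(N)N`, is not yet measured. It differs from compound 3 by methyl in place of hydrogen on a saturated chain carbon bound to an oxygen on an aromatic ring and a saturated chain carbon. The same kind of change separates compound 1 from compound 2, namely (methyl in place of hydrogen on a saturated chain carbon bound to an aromatic carbon and a saturated chain carbon), and there it produced a 1.4-fold higher number from compound 1 to compound 2 (0.15 log units; within the scatter). The two places are not identical: in compound 1 the chain carbon is bound to an aromatic carbon, in compound 3 to an oxygen on an aromatic ring. The cores of compound 1 and compound 3 differ by ethoxy in place of propyl on an aromatic carbon. Resting on compound 1, whose step a 1.4-fold higher number from compound 1 to compound 2 (0.15 log units; within the scatter) stayed within the scatter, the expected step is a 1.3-fold higher number from compound 3 to compound 4 (0.10 log units; within the scatter). Compound 4 is therefore estimated at 24 nM, with a likely range from 10 nM to 55 nM.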

Compound 4, half-maximal inhibitory concentration: 19 nM
For compound 4 the middle estimate is 1.3-fold (0.10 log units) above the measured one; the range from low to high includes it.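

In this assay, the methyl that turns ethoxy into isopropoxy gives no change at the digits printed from compound 3 to compound 4 (within the scatter), while isopropoxy in place of sec-butyl gives a 2.4-fold higher number from compound 2 to compound 4 (0.38 log units; beyond the scatter), and isopropoxy in place of propyl gives a 3.3-fold higher number from compound 1 to compound 4 (0.52 log units; beyond the scatter). Set side by side, the two methyl additions agree: the same change on two cores in this assay, a 1.4-fold higher number (0.15 log units; within the scatter) from compound 1 to compound 2 and no change at the digits printed (within the scatter) from compound 3 to compound 4, 1.4-fold (0.15 log units) apart, within the scatter of two such steps. So on these two cores the added methyl moved the number by no more than the scatter, but two pairs do not show that this holds on other cores in the series.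

The compounds shown leave open what a longer chain, such as butoxy, would do at this place. They also leave open the effect of an amine or a carboxylic acid there.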